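Swapping Chloro for Fluoro on a Shared Core

The source may hold more compounds than are shown below. What is called first, only, known or untested is meant among the compounds shown, and "the series" means these compounds.

Compound 1, `O=C(NNc1cccc(Cl)c1)c1cccc(NS(=O)(=O)c2cnc(O)nc2O)c1`: 7760 nM
Compound 2, `CCCCOc1ccc(C(=O)NNC(=O)c2cccc(NS(=O)(=O)c3cnc(O)nc3O)c2)cc1`: 17000 nM
Compound 3, `O=C(NNC(=O)c1ccccc1Cl)c1cccc(NS(=O)(=O)c2cnc(O)nc2O)c1`: 2360 nM

In a functional assay on MDA-MB-231 cells (Homo sapiens) for antiproliferative activity, read by MTT assay, with a stated time of 24 h (a higher number here means a weaker inhibitor, a lower number a stronger inhibitor), compound 3 gives the lowest of the three numbers, with a 3.3-fold lower number from compound 1 to compound 3 (0.52 log units; beyond the scatter) and a 7.2-fold lower number from compound 2 to compound 3 (0.86 log units; beyond the scatter) both beyond the scatter. Compound 4, `O=C(NNC(=O)c1ccccc1F)c1cccc(NS(=O)(=O)c2cnc(O)nc2O)c1`, keeps the shared core and differs from compound 3 only by fluoro in place of chloro on an aromatic carbon. Neither measured step bears directly on this exchange: each replaced the whole group on the carbonyl or amine nitrogen rather than one substituent on the same ring, so nothing measured points in either direction. Compound 4 is therefore expected to land close to compound 3. Compound 4 is estimated at 3000 nM, with a range from 1200 nM to 8000 nM. The expected step of a 1.3-fold higher number from compound 3 to compound 4 (0.10 log units; within the scatter) is judged to lie within the usual scatter.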

Compound 4, half-maximal inhibitory concentration: > 20000 nM
Compound 4 was reported as a limit; the forecaster's own chance of this, stated with the estimate: 2%; at least 6.6-fold (0.82 log units) between middle value and limit.
By their numbers in this assay, from the lowest: compound 3; then compound 1; then compound 2. At a limit, above all of these: compound 4.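

In this assay compound 4 is reported only as a limit, > 20000 nM. At this position, on an aromatic carbon ortho to a large group, exchanging one halogen atom matters far more than the opening comparison could show: the step reads an at least 8.4-fold higher number from compound 3 to compound 4 (0.92 log units; beyond the scatter). Compound 4 also clears compound 1, at an at least 2.5-fold higher number from compound 1 to compound 4 (0.41 log units; beyond the scatter), whereas an at least 1.1-fold higher number from compound 2 to compound 4 (0.07 log units; that floor lies within the scatter) fixes no firm order between those two compounds.

Going by these compounds, what a bromo or a methyl group would give at this position stays open. The compounds shown also do not explain why this single atom counts so much.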